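The source may report more compounds than this note shows. Statements on the series, on what has been measured and on what is new or still open speak of the compounds shown alone.

Measured so far:
Compound 1 `Cc1nc(C(F)(F)F)ccc1S(=O)(=O)N1CCN(c2ccc(C(=O)NCc3ccc(F)cc3)nn2)CC1`; in an ADME assay on microsomes from liver (Mus musculus) for metabolic stability, read by LC-MS, using NADPH, tested at 10 uM (a lower number here means that the compound disappears faster, a higher number that the compound lasts longer), compound 1 gives 0.383 h.
Compound 2 `Cc1ccccc1S(=O)(=O)N1CCN(c2ccc(C(=O)NCc3ccc(F)cc3)nn2)CC1`; compound 2 gives 0.433 h.

Compound 2 stands alongside compound 1: the two numbers lie within the scatter of each other, as a 1.1-fold higher number from compound 1 to compound 2 (0.05 log units; within the scatter) shows. Compound 3 `Nc1ncccc1S(=O)(=O)N1CCN(c2ccc(C(=O)NCc3ccc(F)cc3)nn2)CC1` differs from compound 2 by 2-aminopyridin-3-yl in place of 2-methylphenyl on a sulfonyl sulfur. Among the measured compounds shown here, the only measured step that bears on this change is the earlier swap on the same sulfonyl sulfur, a 1.1-fold higher number from compound 1 to compound 2 (0.05 log units; within the scatter), which stayed within the scatter; no step beyond the scatter is therefore expected in this assay, in either direction. Compound 3 is expected to give 0.42 h, between 0.2 h and 0.85 h. The step expected is a 1.0-fold lower number from compound 2 to compound 3 (0.01 log units; within the scatter).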

Compound 3, half-life: 0.317 h
For compound 3 the middle estimate is 1.3-fold (0.12 log units) above the measured one, and the stated range covers the measured number.
By their numbers in this assay, from the lowest: compounds 3, 1 and 2 (each within the scatter of the next).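

In this assay, 2-aminopyridin-3-yl on a sulfonyl sulfur leaves the half-life within the scatter of both earlier compounds (a 1.4-fold lower number from compound 2 to compound 3 (0.14 log units; within the scatter); a 1.2-fold lower number from compound 1 to compound 3 (0.08 log units; within the scatter)). Hydrogen-bond donor and acceptor counts at this position thus differ from those of 2-methylphenyl without a step beyond the scatter, and all three groups read alike here. Nothing measured here explains this flat reading. Still open, from the compounds shown here alone, is whether a non-aromatic group on the sulfonyl sulfur, such as cyclopropyl or a carboxylic acid, would move the half-life beyond the scatter. Also open, going by these compounds, is whether any step at this position would appear on a different core.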